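Allyl thioether in place of the benzothiophenylmethyl group

The source may hold more compounds than are shown below. What is called first, only, known or untested is meant among the compounds shown, and "the series" means these compounds.

Measured so far in a functional assay on PC-9 cells (Homo sapiens) for inhibition, read by MTT assay, with a stated time of 72 h; a higher number here means a weaker inhibitor, a lower number a stronger inhibitor:
compound 1 `Cc1cc(Nc2cc(-c3ccccc3)[nH]n2)n2nc(SCc3csc4ccccc34)nc2n1`: 4420 nM
compound 2 `CCCCCc1c(C)nc2nc(SCc3ccc(Cl)cc3)nn2c1Nc1cc(-c2ccccc2)[nH]n1`: a limit only
compound 3 `Cc1cc(Nc2ccn(Cc3ccc(C(F)(F)F)cc3)n2)n2nc(SCc3ccc(Br)cc3)nc2n1`: 5580 nM

Compound 1 and compound 3 lie within the usual scatter of each other in this assay; neither can be set apart. Compound 2 is reported only as a limit, > 50000 nM, which is the limit of > 50000 nM in this assay, at which 1 of the 3 values shown sits.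

Compound 4 `C=CCSc1nc2nc(C)cc(Nc3cc(-c4ccccc4)[nH]n3)n2n1` keeps the core of compound 1 and differs in one place: vinyl in place of 1-benzothiophen-3-yl on a saturated chain carbon bound to a sulfur. Among the compounds with values here, no measured pair on hand shows a comparable change, so the step is expected rather than known. Removing the larger ring system is expected to weaken inhibition, and the step from compound 1 to compound 4 in this assay is estimated as a 3.4-fold higher number from compound 1 to compound 4 (0.53 log units; beyond the scatter). For compound 4 the expected value is 15000 nM, with a range from 5000 nM to 50000 nM.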

Compound 4, half-maximal inhibitory concentration: > 50000 nM
Compound 4: only a limit was reported (the forecaster's own chance of this, stated with the estimate: 25%); middle value at least 3.3-fold (0.52 log units) from the limit.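

On the saturated chain carbon bound to a sulfur, vinyl in place of 1-benzothiophen-3-yl gives an at least 11-fold higher number from compound 1 to compound 4 (1.05 log units; beyond the scatter) in this assay. Within the data shown here, this is the first one-place change read, and it shows that activity on the core of compound 1 depends strongly on the group at this position. Compound 4 is reported only as a limit, > 50000 nM, so the full size of the step stays unknown, and the limit now holds for more than one compound: the limit of > 50000 nM in this assay, at which 2 of the 4 values shown sit.

Going by these compounds, whether the loss follows from the missing aromatic rings or from the shorter group alone remains open. A cyclohexylmethyl group or a longer chain ending in an amine at this position could separate the two.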